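Swapping diethylamino for 4-methylpiperazin-1-yl at the cytotoxicity limit

This account rests on a few compounds, and the source may have more. Where it says the series, first, only, none or still open, it means among the compounds named here.

All three measured compounds in an ADME assay on MT4 cells (Homo sapiens) for cytotoxicity, read by MTT assay, with a stated time of 4 days (on this read-out lower numbers stand for higher toxicity in this test and higher numbers for lower toxicity in this test), are reported only as limits. Compound 1 (`CCN(CC)c1nc(Cc2c(F)cccc2F)cc(=O)[nH]1`) gives > 85000 nM as a limit. Compound 2 (`CC1CCCN(c2nc(Cc3c(F)cccc3F)cc(=O)[nH]2)C1`) gives > 78000 nM as a limit. Compound 3 (`CCN(CC)c1nc(Cc2c(F)cccc2F)c(C)c(=O)[nH]1`) gives > 81000 nM as a limit too, and no rank can be read for it.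

Compound 4 (`Cc1c(Cc2c(F)cccc2F)nc(N2CCN(C)CC2)[nH]c1=O`) carries 4-methylpiperazin-1-yl in place of diethylamino on an aromatic carbon. For the measured compounds named here, the nearest precedent, which also replaces diethylamino, is a step that the two limits leave unreadable from compound 1 to compound 2 with no size to carry over. The methyl addition already present in compound 3 is a step that the two limits leave unreadable from compound 1 to compound 3 and offers no size either. Neither step points in a direction, so no step beyond the scatter is expected in this assay for this replacement. The expected change is an at least 1.0-fold lower number from compound 3 to compound 4 (0.03 log units; that floor lies within the scatter) and it remains a weak expectation. Compound 4 is estimated at 75000 nM (expected range 30000 nM to 150000 nM) and will probably again be reported as a limit.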

Compound 4, half-maximal cytotoxic concentration: > 75000 nM
Compound 4 ended at the assay's limit; the forecaster's own chance of this, stated with the estimate: 75%; the middle value lies on the limit itself.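

In this assay compound 4 gives > 75000 nM, which is a limit. For the compounds shown here, compound 3 also stands only as a limit, so no step between compound 3 and compound 4 can be read. The compounds shown leave open whether 4-methylpiperazin-1-yl in place of diethylamino changes the cytotoxic concentration at all.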